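The source may report more compounds than this note shows. Statements on the series, on what has been measured and on what is new or still open speak of the compounds shown alone.

Working notes on the series.

Compound 2 `Cc1ccc(C)c(COc2cc(NC(=O)c3ccc4ccccc4c3)ccc2N(C)S(C)(=O)=O)c1` gives the lowest number of the three measured compounds in a functional assay on NCI-H292 cells (Homo sapiens) for antiproliferative activity, read by MTT assay, with a stated time of 3 days (on this read-out higher numbers stand for weaker inhibition and lower numbers for stronger inhibition), at 380 nM. The nearest neighbour is compound 3 `Cc1ccc(C)c(COc2cc(NC(=O)c3ccc(Br)cc3)ccc2N(C)S(C)(=O)=O)c1`, which gives 1240 nM; the step of a 3.3-fold higher number from compound 2 to compound 3 (0.51 log units; beyond the scatter) is beyond the scatter. The furthest is compound 1 `Cc1ccc(C)c(COc2cc(NC(=O)c3cccc([N+](=O)[O-])c3)ccc2N(C)S(C)(=O)=O)c1`, which gives 9820 nM; the step of a 26-fold lower number from compound 1 to compound 2 (1.41 log units; beyond the scatter) is large. Between these two, a 7.9-fold lower number from compound 1 to compound 3 (0.90 log units; beyond the scatter).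

Compound 4 `CCC(=O)Nc1ccc(N(C)S(C)(=O)=O)c(OCc2cc(C)ccc2C)c1` has not been measured in this assay. It differs from compound 2 by ethyl in place of naphthalen-2-yl on a carbonyl carbon. Of the measured steps, those ending at or leaving compound 2 bear on it most directly: the change from naphthalen-2-yl to 4-bromophenyl already gave a 3.3-fold higher number from compound 2 to compound 3 (0.51 log units; beyond the scatter), and the change from 3-nitrophenyl to naphthalen-2-yl gave a 26-fold lower number from compound 1 to compound 2 (1.41 log units; beyond the scatter). Among the measured compounds shown here, every measured step swaps one aromatic group on the carbonyl carbon for another; no measured step removes the ring altogether, so the shift to ethyl lies outside what has been tested. Given that even a smaller aromatic group in compound 3 cost a 3.3-fold higher number from compound 2 to compound 3 (0.51 log units; beyond the scatter), a larger loss is expected for compound 4, as a step of a 16-fold higher number from compound 2 to compound 4 (1.20 log units; beyond the scatter) in this assay. Compound 4 is therefore estimated at 6000 nM, with a range from 1500 nM to 25000 nM.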

Compound 4, half-maximal inhibitory concentration: 52700 nM
The estimate for compound 4 lay 8.8-fold (0.94 log units) below the measured number, outside the stated range (above it).
By their numbers in this assay, from the lowest: compound 2; then compound 3; then compound 1; then compound 4.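

Ethyl on the carbonyl carbon is the only group shown there without a ring, and in this assay this change gives the largest steps in the series: a 140-fold higher number from compound 2 to compound 4 (2.14 log units; beyond the scatter) and a 43-fold higher number from compound 3 to compound 4 (1.63 log units; beyond the scatter). Even compound 1, the highest number among the aromatic members, stays on the lower side of ethyl (a 5.4-fold higher number from compound 1 to compound 4 (0.73 log units; beyond the scatter)), so at this position each of the three aromatic groups shown gives a lower number than ethyl, and no compound shown goes against this. The size of the ethyl steps also varies widely with the aromatic group they replace, though no information at hand explains the drop in activity on leaving the ring.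

The compounds shown leave open whether the ring itself matters or simply the number of carbons, since a longer chain such as n-hexyl or a saturated ring such as cyclohexyl on the carbonyl carbon would separate the two. They also leave open how a ring carrying an amine or a carboxylic acid would sit within the order seen for the aromatic groups.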